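This account rests on a few compounds, and the source may have more. Where it says the series, first, only, none or still open, it means among the compounds named here.

Measured in an ADME assay on L929 cells (Mus musculus) for cytotoxicity, read by resazurin assay, with a stated time of 48 h; a lower number here means that less compound is tolerated, a higher number that more compound is tolerated:
- Compound 1 `C=CCn1c2ccc([N+](=O)[O-])cc2c(=O)n1Cc1ccccc1`: 192000 nM
- Compound 2 `O=C(O)CCCn1c2ccc([N+](=O)[O-])cc2c(=O)n1Cc1ccccc1`: > 256000 nM (a limit of the assay, not a number)

Compound 2 stands at the limit of > 256000 nM in this assay, at which 1 of the 2 values shown sits, so its place is known only as a limit. Going by the values given here, the only measured step is an at least 1.3-fold higher number from compound 1 to compound 2 (0.12 log units; that floor lies within the scatter). It puts 2-carboxyethyl in place of vinyl on a saturated chain carbon bound to an aromatic nitrogen, and its floor lies within the scatter.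

Compound 3 `CNC(=O)CCCn1c2ccc([N+](=O)[O-])cc2c(=O)n1Cc1ccccc1` has not yet been measured. It carries methylamino in place of hydroxy on a carbonyl carbon, which turns carboxy into methylcarbamoyl: methylamino in place of hydroxy on a carbonyl carbon. Among the compounds with values here, no measured step covers this change, so the one step available bears on it only indirectly. No step beyond the scatter is therefore expected, in either direction, in this assay. The expectation rests on compound 1, with 192000 nM. It rests also on compound 2, with > 256000 nM, which is a limit of the assay. The step expected from this reasoning is an at least 1.1-fold lower number from compound 2 to compound 3 (0.04 log units; that floor lies within the scatter). For compound 3 the estimated value is 230000 nM, with an expected range from 110000 nM to 460000 nM.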

Compound 3, concentration lethal to 50% of the cells: > 256000 nM
Compound 3 gave a limit, no number; the forecaster's own chance of this, stated with the estimate: 45%; at least 1.1-fold (0.04 log units) between middle value and limit.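

With methylamino in place of hydroxy on a carbonyl carbon, this assay again gives no readable number, so the limit is no longer tied to carboxy alone and is shared by two different ends of the chain: the limit of > 256000 nM in this assay, at which 2 of the 3 values shown sit.

Going by these compounds alone, the one readable new step is an at least 1.3-fold higher number from compound 1 to compound 3 (0.12 log units; that floor lies within the scatter), so this comparison offers only a floor and shows no change beyond the scatter. The step from compound 2 to compound 3 cannot be read, since both values are limits of the assay, and the swap of hydroxy for methylamino therefore has no measured size.

On these data alone, how far either compound lies past the limit stays open, and a wider test range would be needed to tell whether carboxy and methylcarbamoyl differ at all in this assay. Also open, as far as these compounds go, is whether an amine at the end of the chain, a dimethylamino group on the carbonyl carbon or a longer chain would stay at this limit or bring the number back into the readable range, as with compound 1.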